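The source may hold more compounds than are shown below. What is called first, only, known or untested is meant among the compounds shown, and "the series" means these compounds.

Compound 1 `CNCc1cc(-c2cccnc2F)n(S(=O)(=O)c2ccccc2)c1`: 99%
Compound 2 `CNCc1cc(-c2cccnc2F)n(S(=O)(=O)c2cccc(F)c2)c1`: 99%
Compound 3 `CNCc1cc(-c2cccnc2F)n(S(=O)(=O)c2cccc(OC)c2)c1`: 92%

All three were tested in a functional assay on the whole organism (strain Jcl:SD) for inhibition, with Rattus norvegicus as the target, with stated times of 3 min and 3 h, at a dose of 1 mg/kg by the intravenous route; a lower number here means less inhibition, a higher number more inhibition at the dose given (going by the name of the read-out). Compound 3 sits at the low end of the three numbers, but the steps of a number 7 percentage points lower from compound 1 to compound 3 (within the scatter) and a number 7 percentage points lower from compound 2 to compound 3 (within the scatter) both lie within the usual scatter, so the three compounds cannot be told apart on these numbers. Compound 4 `CNCc1cc(-c2cccnc2F)n(S(=O)(=O)c2cccc(C#N)c2)c1` differs from compound 3 by cyano in place of methoxy on an aromatic carbon. Going by the values given here, no measured step swaps methoxy for cyano; the steps that bear on it are no change at the digits printed from compound 1 to compound 2 (within the scatter), a number 7 percentage points lower from compound 1 to compound 3 (within the scatter) and a number 7 percentage points lower from compound 2 to compound 3 (within the scatter), which each changed a group on the same aromatic carbon and stayed within the scatter. The expected step is therefore a number 3 percentage points higher from compound 3 to compound 4 (within the scatter), none beyond the scatter. Compound 4 is estimated at 95%, with a range from 85% to 100%.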

Compound 4, a percentage reported as inhibition, in the whole organism at one dose (the size of the read-out at that dose, not a potency): 99%
For compound 4 the middle estimate is 4 percentage points below the measured one; the range from low to high includes it.
By their numbers in this assay, from the lowest: compounds 3, 1, 2 and 4 (each within the scatter of the next).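

Cyano is a fourth group on this aromatic carbon, and in this assay the swaps give no change at the digits printed from compound 1 to compound 4 (within the scatter) and no change at the digits printed from compound 2 to compound 4 (within the scatter) and also a number 7 percentage points higher from compound 3 to compound 4 (within the scatter) for this series. Hydrogen, fluoro, methoxy and cyano therefore cannot be told apart at this position on these numbers. No independent measurement bears on why these groups read alike. Going by these compounds, whether a carboxylic acid or an amine on this same carbon would separate from these four remains open. A single dose also leaves open how these compounds would compare at lower doses.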